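The source may report more compounds than this note shows. Statements on the series, on what has been measured and on what is new or still open speak of the compounds shown alone.

Values in a physicochemical assay for lipophilicity; on this read-out higher numbers stand for higher lipophilicity and lower numbers for lower lipophilicity

Compound 1 `COc1cc(C2=NO[C@]3(C2)C(=O)O[C@@H]2[C@H]3CC[C@H](C)[C@]3(O)C=CC(=O)[C@@]23C)ccc1O` gives 0.75
Compound 2 `C[C@H]1CC[C@@H]2[C@@H](OC(=O)[C@]23CC(c2ccc(C#N)cc2)N(c2ccccc2)O3)[C@]2(C)C(=O)C=C[C@@]12O` gives 2.94

Of these two compounds, compound 2 stands highest in this assay at 2.94. Compound 1 stands lower at 0.75 on this scale. The gap between these two values lies beyond the scatter. The next compound to be measured is compound 3 `C[C@H]1CC[C@@H]2[C@@H](OC(=O)[C@]23CC(c2cccc(F)c2)N(c2ccccc2)O3)[C@]2(C)C(=O)C=C[C@@]12O` in the same assay. It carries 3-fluorophenyl in place of 4-cyanophenyl on a saturated ring carbon of a five-membered non-aromatic ring with 1 nitrogen and 1 oxygen, and the counted difference is 3-fluorophenyl in place of 4-cyanophenyl on a saturated ring carbon at that one place. The rest of compound 2 stays as it is. Among the measured compounds shown here, no two measured compounds differ in one place only, so no measured step sizes this change, and the expectation rests on the structural change alone. A moderate upward move, somewhat beyond the scatter, is expected, with the estimated step of a number 0.56 log units higher from compound 2 to compound 3 (beyond the scatter) in this read-out. Compound 3 is estimated to reach 3.5 (expected range 3.1 to 3.9).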

Compound 3, partition coefficient: 3.35
Compound 3: the middle estimate sits 0.15 log units above what was measured; measured number inside the range.
By their numbers in this assay, from the lowest: compound 1; then compound 2; then compound 3.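

Compounds 1 and 2 differ in more than one place, so they could not show what a single change does at this position. Compound 3 supplies that first reading: on the saturated ring carbon next to the ring nitrogen, 3-fluorophenyl in place of 4-cyanophenyl gives in this assay a number 0.41 log units higher from compound 2 to compound 3 (beyond the scatter), so this read-out responds to the aryl group at this one place, though the step is modest. Nothing at hand bears on the reason for this move.

The step also changes two things at once, the substituent on the phenyl ring and where it sits, so the compounds shown cannot separate the nitrile-to-fluorine exchange from the shift between the 4- and 3-positions named in these groups. As far as these compounds go, whether 4-fluorophenyl or 3-cyanophenyl would fall with compound 2 or with compound 3 stays open, as does the response of this read-out to an aminophenyl or a carboxyphenyl group at the same ring carbon.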